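Changing the Sulfonyl Aryl Group: Compound 2 to Compound 3

The source may report more compounds than this note shows. Statements on the series, on what has been measured and on what is new or still open speak of the compounds shown alone.

Compound 2 `Cc1ccccc1S(=O)(=O)Nc1ccc(-c2nc3ccccc3o2)cc1` gives 85000 nM in an assay on cells for inhibition of HSP60/HSP10 (Homo sapiens), with a stated time of 60 min; a lower number here means a stronger inhibitor, a higher number a weaker inhibitor. It stands together with compound 1 `COc1cccc(S(=O)(=O)Nc2ccc(-c3nc4ccccc4o3)cc2)c1` at 80000 nM, since the step of a 1.1-fold higher number from compound 1 to compound 2 (0.03 log units; within the scatter) lies within the scatter. Compound 3 `COc1ccc(Cl)cc1S(=O)(=O)Nc1ccc(-c2nc3ccccc3o2)cc1` differs from compound 2 by 5-chloro-2-methoxyphenyl in place of 2-methylphenyl on a sulfonyl sulfur. For the measured compounds named here, the only measured step touching this position is a 1.1-fold higher number from compound 1 to compound 2 (0.03 log units; within the scatter), where exchanging one aryl group on the sulfonyl sulfur for another did not move the number beyond the scatter. For compound 3 in this assay a step of about a 1.4-fold lower number from compound 2 to compound 3 (0.15 log units; within the scatter) is therefore expected, not clearly beyond the scatter. Compound 3 is estimated at 60000 nM, between 20000 nM and 150000 nM.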

Compound 3, half-maximal inhibitory concentration: > 100000 nM
Compound 3: no number, only a limit (the forecaster's own chance of this, stated with the estimate: 20%); middle value at least 1.6-fold (0.22 log units) from the limit.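

Compound 3 gives only a limit of the assay, > 100000 nM, and not a number. Its steps can be read only as floors, an at least 1.1-fold higher number from compound 2 to compound 3 (0.07 log units; that floor lies within the scatter) and an at least 1.2-fold higher number from compound 1 to compound 3 (0.09 log units; that floor lies within the scatter), so neither shows a change beyond the scatter. Even with the larger 5-chloro-2-methoxyphenyl on the sulfonyl sulfur, no lower number appears, and the top of this series can no longer be read exactly: the limit of > 100000 nM in this assay, at which 1 of the 3 values shown sits.

From the compounds shown here alone, whether any group at this position gives a number clearly lower stays open. An amine or a carboxylic acid on the aryl ring, or a longer chain in its place, could still answer that.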